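Dropping the Methoxy Group from a Weak Dichloroacetamide

This account rests on a few compounds, and the source may have more. Where it says the series, first, only, none or still open, it means among the compounds named here.

Three dichloroacetamides have been tested in a functional assay on KB 3-1 cells (Homo sapiens) for cytotoxicity, read by MTT assay, with a stated time of 68 h; a higher number here means a weaker inhibitor, a lower number a stronger inhibitor. Compound 1 `COc1ccc(-c2cc(NC(=O)C(Cl)Cl)cc(-c3ccc(OC)c(F)c3)c2)cc1F`, which carries two substituted aryl groups on its core, gives 2940 nM. Compound 3 `O=C(Nc1cc(-c2ccc(OC3CCCCO3)cc2)cc(-c2ccc(OC3CCCCO3)cc2)c1)C(Cl)Cl`, also with two aryl groups, gives 7220 nM. Compound 2 `COc1cccc(-c2cccc(NC(=O)C(Cl)Cl)c2)c1`, with a single methoxy-bearing phenyl group, gives 43300 nM. Among these three numbers compound 2 stands highest, so it is the weakest inhibitor of the set; its nearest neighbour is compound 3 and its most distant is compound 1, and both gaps lie beyond the scatter of repeated measurements.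

Compound 4 `O=C(Nc1cccc(-c2ccccc2)c1)C(Cl)Cl` is the next candidate. It differs from compound 2 in one place: hydrogen in place of methoxy on an aromatic carbon. Among the compounds with values here, no measured pair in this set shows this change, so the expectation rests on the general picture only. Since compound 2 already sits at the weak end, the step is expected to be small, in the direction of a slightly higher number, as a 1.4-fold higher number from compound 2 to compound 4 (0.14 log units; within the scatter). Compound 4 is therefore expected to give about 60000 nM, within a range from 20000 nM to 200000 nM.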

Compound 4, half-maximal inhibitory concentration: 46800 nM
Beside the measured number, compound 4's estimate is 1.3-fold (0.11 log units) above it; measured number inside the range.
By their numbers in this assay, from the lowest: compound 1; then compound 3; then compounds 2 and 4 (each within the scatter of the next).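

In this assay, putting hydrogen in place of methoxy on this aromatic carbon, meta to a large group, gives a 1.1-fold higher number from compound 2 to compound 4 (0.03 log units; within the scatter) and so leaves the two numbers indistinguishable. Within the data shown here, the earlier compounds included no pair differing in one place, so this is the first direct reading of a single change in the set, and it shows that the methoxy group can go without a measurable shift in this assay at this position. No measurement at hand accounts for this result.

Going by these compounds, whether an amine, a carboxylic acid or a longer chain such as butoxy on the same carbon would move the number remains open. On these data alone, it is also open whether removing a methoxy group would have as little effect on a compound with two aryl groups, such as compound 1.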